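This account rests on a few compounds, and the source may have more. Where it says the series, first, only, none or still open, it means among the compounds named here.

Measured in a functional assay on Daudi cells (Homo sapiens) for antiproliferative activity; on this read-out higher numbers stand for weaker inhibition and lower numbers for stronger inhibition:
- compound 1 `Nc1ncnc2c1c(-c1ccc(Oc3ccccc3)cc1)cn2C[C@H]1CCCN1C[C@@H](O)CO`: 14400 nM
- compound 2 `Nc1ncnc2c1c(-c1ccc(Oc3ccccc3)cc1)cn2C[C@H]1CCCN1C(CO)CO`: 28200 nM
- compound 3 `Nc1ncnc2c1c(-c1ccc(Oc3ccccc3)cc1)cn2C[C@H]1CCCN1C[C@@H]1CO1`: 7040 nM

In this assay compound 3 has the lowest number of the three, which makes it the strongest inhibitor in this small set. The two steps leading to it are a 2.0-fold lower number from compound 1 to compound 3 (0.31 log units; beyond the scatter) and a 4.0-fold lower number from compound 2 to compound 3 (0.60 log units; beyond the scatter). Both are modest. The remaining step, a 2.0-fold higher number from compound 1 to compound 2 (0.29 log units; within the scatter), stays within the scatter.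

Compound 4 `Nc1ncnc2c1c(-c1ccc(Oc3ccccc3)cc1)cn2[C@H]1CCN(C[C@H]2CO2)C1` has not yet been measured. In it, 1-((oxiran-2-yl)methyl)pyrrolidin-3-yl takes the place of (1-((oxiran-2-yl)methyl)pyrrolidin-2-yl)methyl on an aromatic nitrogen (1-((oxiran-2-yl)methyl)pyrrolidin-3-yl in place of (1-((oxiran-2-yl)methyl)pyrrolidin-2-yl)methyl on an aromatic nitrogen). The (oxiran-2-yl)methyl group on the amine nitrogen in the ring stays as it is in compound 3.

All three measured steps change the group on that amine nitrogen, so none of them tests the change made here. Among the compounds with values here, they show only that changes elsewhere in this part of the molecule have so far been modest, the largest being a 4.0-fold lower number from compound 2 to compound 3 (0.60 log units; beyond the scatter). With no direct evidence for a direction, no step beyond the scatter is expected in this assay, though the uncertainty is wide. The expected step is a 1.2-fold lower number from compound 3 to compound 4 (0.07 log units; within the scatter). The estimate for compound 4 is 6000 nM, with an expected range of 2000 nM to 18000 nM.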

Compound 4, half-maximal inhibitory concentration: 15700 nM
For compound 4 the middle estimate is 2.6-fold (0.42 log units) below the measured one; measured number inside the range.
By their numbers in this assay, from the lowest: compound 3; then compounds 1, 4 and 2 (each within the scatter of the next).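

Within the data shown here, compound 4 is the first compound here to change how the ring is attached to the aromatic nitrogen while the (oxiran-2-yl)methyl group on the amine nitrogen stays the same. In this assay, putting 1-((oxiran-2-yl)methyl)pyrrolidin-3-yl in place of (1-((oxiran-2-yl)methyl)pyrrolidin-2-yl)methyl gives a modest step (a 2.2-fold higher number from compound 3 to compound 4 (0.35 log units; beyond the scatter)), so this position does respond, though not strongly, and the attachment matters as well as the group on the amine nitrogen. With the new attachment, the compound bearing the oxirane no longer stands apart from the two compounds bearing hydroxyl groups, with steps (a 1.8-fold lower number from compound 2 to compound 4 (0.25 log units; within the scatter)) and (a 1.1-fold higher number from compound 1 to compound 4 (0.04 log units; within the scatter)) that both stay within the scatter, and nothing measured here accounts for the modest step from compound 3.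

Still open, as far as these compounds go, is whether 2,3-dihydroxypropyl on the amine nitrogen of the pyrrolidin-3-yl ring would give the same number as the oxirane does there, which would show if that group still counts with this attachment. Also open, from the compounds shown here alone, is how the opposite stereocentre on the pyrrolidin-3-yl ring, a larger piperidin-3-yl ring or a longer chain to the aromatic nitrogen would fare.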